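4-phenylpiperazin-1-yl in place of butyl in compound 2

A few compounds are considered here, and "the series" means these few. Any claim that something is new, unique, unknown or untested is made for them only; others in the source may bear on it.

Among the compounds with values here, in a functional assay on the whole organism for antagonist activity, with Mus musculus as the target (a lower number here means that less compound is needed, a higher number that more compound is needed for the effect), compound 2 (`CCCCCC(=O)NCC(=O)N(C)c1ccc(Cl)cc1C(=O)c1ccccc1Cl`) gives 1.9 mg/kg, the lowest of the three numbers so far. Compound 1 (`CC(=O)NCC(=O)Nc1ccc(Cl)cc1C(=O)c1ccccc1`) gives 37 mg/kg and compound 3 (`NC(C(=O)NCC(=O)Nc1ccc(Cl)cc1C(=O)c1ccccc1)c1ccccc1`) gives 28 mg/kg.

Compound 4 (`CN(C(=O)CNC(=O)CN1CCN(c2ccccc2)CC1)c1ccc(Cl)cc1C(=O)c1ccccc1Cl`) has 4-phenylpiperazin-1-yl in place of butyl on a saturated chain carbon bound to a carbonyl carbon.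

Within the data shown here, no measured step starts from compound 2. Among the measured compounds shown here, the one step that bears on this change is amino(phenyl)methyl in place of methyl on a carbonyl carbon, a 1.3-fold lower number from compound 1 to compound 3 (0.12 log units; within the scatter). It shows a larger group with a ring entering without a shift beyond the scatter. However, compound 1 and compound 3 differ from compound 2 elsewhere as well, so this guide is loose. In this assay no step beyond the scatter is therefore expected, only a slight rise at most. The estimated step is a 1.6-fold higher number from compound 2 to compound 4 (0.20 log units; within the scatter). For compound 4 the estimate is 3 mg/kg, with an expected range from 0.8 mg/kg to 12 mg/kg.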

Compound 4, dose for half-maximal effect: 75 mg/kg
Compound 4: the middle estimate sits 25-fold (1.40 log units) below what was measured; measured number above the stated range.
By their numbers in this assay, from the lowest: compound 2; then compounds 3 and 1 (each within the scatter of the next); then compound 4.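

At this position, on a saturated chain carbon bound to a carbonyl carbon, the group that enters matters greatly in this assay: 4-phenylpiperazin-1-yl in place of butyl gives a 39-fold higher number from compound 2 to compound 4 (1.60 log units; beyond the scatter), the first listed single change beyond the scatter. Within the data shown here, the only earlier step, a 1.3-fold lower number from compound 1 to compound 3 (0.12 log units; within the scatter), brought in a ring-bearing group on a carbonyl carbon in another compound pair without a shift beyond the scatter, and that tolerance does not hold for this change. No measurement at hand explains the rise.

Still open, as far as these compounds go, is whether the rise belongs to the piperazine ring, its phenyl group or the overall size of the new group. A longer carbon chain, a dimethylamino group or an unsubstituted piperazine on the same carbon would separate these readings.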